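The compounds below may be only part of what the source reports. "The series", "measured", "known", "first", "only" and "open" are said of these compounds alone.

In a functional assay on HL-60 cells (Homo sapiens) for antiproliferative activity, read by MTT assay, with a stated time of 48 h (a lower number here means a stronger inhibitor, a higher number a weaker inhibitor), compound 1 `CCN(CC)C/C1=C/C[C@](C)(CCC=C(C)C)/C=C/[C@@H](OC(=O)C=C(C)C)[C@](C)(O)/C=C/C1=O` gives 140 nM, and compound 2 `CC(C)=CCC[C@]1(C)/C=C/[C@@H](OC(=O)C=C(C)C)[C@](C)(O)/C=C/C(=O)/C(CN=[N+]=[N-])=C\C1` gives 910 nM, the higher of the two numbers, which makes it the weaker inhibitor of the measured pair. Compound 3 `CCN(CC)C(=O)/C1=C/C[C@](C)(CCC=C(C)C)/C=C/[C@@H](OC(=O)C=C(C)C)[C@](C)(O)/C=C/C1=O` keeps the shared core of compound 2 but carries diethylcarbamoyl in place of azidomethyl on a double-bonded ring carbon. Among the compounds with values here, only one measured step bears on this change: a 6.5-fold higher number from compound 1 to compound 2 (0.81 log units; beyond the scatter). It is modest but beyond the scatter, and it came from azido taking the place of diethylamino on a saturated chain carbon bound to a double-bonded ring carbon. That step shows that the number can move with a change at this part of the molecule. However, no measured compound carries diethylcarbamoyl, so the data give no firm direction for the new group. A step no larger than the measured one is therefore expected in this assay, quite possibly none beyond the scatter. The estimated step is a 1.1-fold lower number from compound 2 to compound 3 (0.06 log units; within the scatter). The estimate for compound 3 is 800 nM, with an expected range of 250 nM to 2500 nM.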

Compound 3, half-maximal inhibitory concentration: 9080 nM
For compound 3 the middle estimate is 11-fold (1.05 log units) below the measured one; measured number outside the range, above it.
By their numbers in this assay, from the lowest: compound 1; then compound 2; then compound 3.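

In this assay the earlier compounds showed only that the number can move at this double-bonded ring carbon, whereas diethylcarbamoyl now gives a 10-fold higher number from compound 2 to compound 3 (1.00 log units; beyond the scatter) and, against (diethylamino)methyl, gives a 65-fold higher number from compound 1 to compound 3 (1.81 log units; beyond the scatter) as the largest step among these compounds. Compound 1 and compound 3 both carry the diethyl-substituted nitrogen, so that nitrogen alone does not keep the number low; the two differ by a carbonyl in place of the saturated chain carbon bound to the ring. No measurement at hand gives a reason for either step.

The compounds shown leave open whether the low number of compound 1 extends to other amines on that saturated chain carbon, such as dimethylamino, pyrrolidine or morpholine, or to a longer chain between the ring carbon and the nitrogen. They also leave open whether other carbonyl groups on the ring carbon, such as a primary amide, a methyl ester or a carboxylic acid, would stay as high as compound 3 or fall back toward the azidomethyl and (diethylamino)methyl compounds.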